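From 2,4-difluorophenyl to 3,5-difluorophenyl in compound 3

The source may report more compounds than this note shows. Statements on the series, on what has been measured and on what is new or still open speak of the compounds shown alone.

In a functional assay on the whole organism for inhibition, with Lemna aequinoctialis as the target, with a stated time of 7 days, tested at 50 ug/mL (a lower number here means less inhibition of growth, a higher number more inhibition of growth at the concentration tested), compound 1 `O=C1Nc2ccc(F)cc2/C1=N/NC(=S)Nc1ccc(F)cc1` gives 25%, and compound 2 `O=C1Nc2ccc(F)cc2/C1=N/NC(=S)Nc1ccc(F)cc1F` gives 20%. These two numbers lie within the usual scatter of each other, so compound 2 stands on a par with compound 1 and the pair cannot be ranked. Compound 3 `O=C1Nc2ccc(F)cc2/C1=N/NC(=S)Nc1cc(F)cc(F)c1` keeps the shared core and differs from compound 2 only in the group on the amide-type nitrogen, with 3,5-difluorophenyl in place of 2,4-difluorophenyl on an amide-type nitrogen. The atoms stay the same and only their arrangement changes. Among the compounds with values here, no measured step makes this exact change. Within the data shown here, the nearest evidence is the single step available, a number 5 percentage points lower from compound 1 to compound 2 (within the scatter), which did not exceed the scatter. On that slim basis, no shift beyond the scatter is expected in this assay, and neither direction is clearly favoured. The expected change is a number 2 percentage points higher from compound 2 to compound 3 (within the scatter), which stays within the scatter. Compound 3 is estimated at 22%, with an expected range from 8% to 38%.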

Compound 3, percent growth inhibition at one concentration: 10%
Estimate against measurement, compound 3: 12 percentage points above; the range from low to high includes it.
By their numbers in this assay, from the lowest: compounds 3, 2 and 1 (each within the scatter of the next, the first and the last beyond it).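

In this assay, exchanging 2,4-difluorophenyl for 3,5-difluorophenyl on the amide-type nitrogen gives a number 10 percentage points lower from compound 2 to compound 3 (within the scatter), so these two arrangements of the same atoms cannot be ranked. Within the data shown here, the comparison with 4-fluorophenyl at the same place gives a number 15 percentage points lower from compound 1 to compound 3 (beyond the scatter), the first step at this position to pass the scatter, though only modestly, and it shows that the group on this nitrogen can alter growth inhibition at the concentration tested. Nothing available explains this step.

The compounds shown carry only fluorinated phenyl groups on the amide-type nitrogen, so they leave open whether an unsubstituted phenyl, a methoxyphenyl, an aminophenyl or a carboxyphenyl group there would give a clearly different result in this assay. They also leave open whether a non-aromatic group such as cyclohexyl or a longer alkyl chain at that place would move the number beyond the scatter, in either direction, from the value of compound 3 at 10%.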